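Trading the large aryl substituent for a small ester

The compounds below may be only part of what the source reports. "The series", "measured", "known", "first", "only" and "open" are said of these compounds alone.

Of the compounds shown here, three sharing one core have been measured. Compound 1 `CCCCCCCCc1ccc(OCC(=O)Cn2nnc(C(=O)O)n2)cc1` gives 41 nM in an assay on microsomes from brain for inhibition of Fatty-acid amide hydrolase 1 (Rattus norvegicus), read by fluorescence and HPLC, with a stated time of 60 min (a higher number here means a weaker inhibitor, a lower number a stronger inhibitor), and compound 2 `CCCCCCCCc1ccc(OCC(=O)Cn2nnnc2C)cc1` gives 41 nM in this assay. Compound 3 `CCCCCCCCc1ccc(OCC(=O)Cn2nnnc2-c2ccc(S(=O)(=O)N(C)C)cc2)cc1` gives 1400 nM in this assay, the highest of the three numbers, set apart from both others by the same margin; the step of a 34-fold higher number from compound 2 to compound 3 (1.53 log units; beyond the scatter) shows this, while the step of no change at the digits printed from compound 1 to compound 2 (within the scatter) shows that the two small substituents behave alike.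

Compound 4 `CCCCCCCCc1ccc(OCC(=O)Cn2nnnc2C(=O)OC)cc1` is not yet measured. It differs from compound 3 by methoxycarbonyl in place of 4-(dimethylsulfamoyl)phenyl on an aromatic carbon. This change essentially undoes the substitution that separated compound 2 from compound 3, again leaving a small group in place of the large aryl group, and the two small groups already seen, carboxy in compound 1 and methyl in compound 2, gave the same number. A large step downward is therefore expected, with compound 4 estimated at 60 nM, within 20 nM to 250 nM, corresponding to the expected step of a 23-fold lower number from compound 3 to compound 4 (1.37 log units; beyond the scatter) in this assay.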

Compound 4, half-maximal inhibitory concentration: 1000 nM
Beside the measured number, compound 4's estimate is 17-fold (1.22 log units) below it; the measured number lies above the stated range.
By their numbers in this assay, from the lowest: compounds 1 and 2 (each within the scatter of the next); then compounds 4 and 3 (each within the scatter of the next).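

In this assay, giving up the ring of 4-(dimethylsulfamoyl)phenyl for methoxycarbonyl brings no clear gain, a 1.4-fold lower number from compound 3 to compound 4 (0.15 log units; within the scatter), so a large aryl group is not needed for a high number at this aromatic carbon. Methoxycarbonyl instead stands well apart from methyl at the same carbon, a 24-fold higher number from compound 2 to compound 4 (1.39 log units; beyond the scatter), and the 5-(methoxycarbonyl)-1H-tetrazol-1-yl group stands equally far from the 5-carboxy-2H-tetrazol-2-yl group, a 24-fold higher number from compound 1 to compound 4 (1.39 log units; beyond the scatter), so the low numbers of compound 1 and compound 2 do not extend to every group without a ring. No measurement at hand explains this difference.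

On these data alone, it remains open how a carboxylic acid would behave on this same aromatic carbon, with the attachment of compound 4 kept. An ethyl group or a primary amide at this carbon would show whether the number stays near that of compound 2 or that of compound 4.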